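Chloro to methyl on the shared core

The compounds below may be only part of what the source reports. "The series", "measured", "known", "first", "only" and "open" are said of these compounds alone.

Of the compounds shown here, three have been read so far in an ADME assay on microsomes from liver (Rattus norvegicus) for metabolic stability; on this read-out lower numbers stand for a shorter-lived compound and higher numbers for a longer-lived compound. Compound 2 `CC#C[C@@H](Cc1nnn[nH]1)c1ccc(OCc2cc(Cl)c3scc(-c4ccccc4C)c3c2)cc1` gives 0.117 h. Compound 1 `CC#C[C@@H](Cc1nnn[nH]1)c1ccc(OCc2ccc3scc(-c4cccnc4C)c3c2)cc1` gives 0.183 h, which lies within the scatter of compound 2. Compound 3 `CC#C[C@@H](Cc1nnn[nH]1)c1ccc(OCc2ccc3sc(F)c(-c4ccc(OCCOC)cc4C)c3c2)cc1` gives 0.35 h, which stands higher than compound 2 by more than the scatter. Compound 2 therefore sits at the low end of the numbers in this small set, together with compound 1.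

These three compounds differ from one another in more than one place. Among the compounds with values here, no measured pair isolates a single change, and this assay offers no direct precedent for the next substitution.

Compound 4 `CC#C[C@@H](Cc1nnn[nH]1)c1ccc(OCc2cc(C)c3scc(-c4ccccc4C)c3c2)cc1` departs from compound 2 in one place only: methyl in place of chloro on an aromatic carbon. This is methyl in place of chloro on an aromatic carbon, and the rest of the structure stays the same.

Within the data shown here, with no measured step to draw on, the expectation rests on compound 2 at 0.117 h, and neither direction is favoured. The expected step, a 1.0-fold higher number from compound 2 to compound 4 (0.01 log units; within the scatter), is estimated to stay within the scatter. Compound 4 is estimated at 0.12 h, with an expected range from 0.06 h to 0.24 h.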

Compound 4, half-life: < 0.0667 h
Compound 4 ended at the assay's limit; the forecaster's own chance of this, stated with the estimate: 3%; middle value at least 1.7-fold (0.25 log units) away from the limit.
By their numbers in this assay, from the lowest: compounds 2, 1 and 3 (each within the scatter of the next, the first and the last beyond it). At a limit, below all of these: compound 4.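

In this assay, within the data shown here, methyl in place of chloro on an aromatic carbon gives an at least 1.7-fold lower number from compound 2 to compound 4 (0.24 log units; that floor lies within the scatter), the first step that isolates a single change. Compound 4 stands at a limit of the assay and not at a number: the limit of < 0.0667 h in this assay, at which 1 of the 4 values shown sits. At this place, ortho to a fused ring and meta to a large group, the step gives no sign that methyl lengthens the half-life relative to chloro, but the limit leaves its true size unknown, so it cannot be said whether the full step stays within the scatter or goes beyond it.

The compounds shown leave open how a hydrogen, a nitrile or a trifluoromethyl at this place would read with the rest of compound 2 kept unchanged, and a value above the limit for a close relative of compound 4 would be needed to put a size on any such step. They also leave open whether the same exchange of chloro for methyl would read the same way on the cores of compound 1 or compound 3.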